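Carbamate series: butoxycarbonyl replacing methoxy on the aryl ring

The source may hold more compounds than are shown below. What is called first, only, known or untested is meant among the compounds shown, and "the series" means these compounds.

Measured so far in a functional assay on RAW264.7 cells (Mus musculus) for inhibition, with a stated time of 30 min; a higher number here means a weaker inhibitor, a lower number a stronger inhibitor:
compound 1 `C=C1C(=O)OC[C@H]1CCOC(=O)Nc1ccc(C(=O)OCCCC)cc1`: 430 nM
compound 2 `C=C1C(=O)OC[C@@H]1CCOC(=O)Nc1ccc(C(C)C)cc1`: 1580 nM
compound 3 `C=C1C(=O)OC[C@@H]1CCOC(=O)Nc1ccc(OC)cc1`: 1090 nM

Compound 3 stands second highest of the three numbers; it sits within the scatter of compound 2 and gives a number beyond the scatter above compound 1. Compound 4 `C=C1C(=O)OC[C@@H]1CCOC(=O)Nc1ccc(C(=O)OCCCC)cc1` is the next step: butoxycarbonyl in place of methoxy on an aromatic carbon. Among the compounds with values here, the only measured step at this aromatic carbon is a 1.4-fold lower number from compound 2 to compound 3 (0.16 log units; within the scatter), which says little. Compound 1 bears the same butoxycarbonyl and gives 430 nM in this assay, the lowest number shown, so a lower number is expected for compound 4, though the remainder of compound 1 is not identical to compound 4. The estimate for compound 4 is 500 nM, range 200 nM to 1300 nM, a step of a 2.2-fold lower number from compound 3 to compound 4 (0.34 log units; beyond the scatter).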

Compound 4, half-maximal inhibitory concentration: 860 nM
The estimate for compound 4 lay 1.7-fold (0.24 log units) below the measured number; the range from low to high includes it.
By their numbers in this assay, from the lowest: compounds 1, 4, 3 and 2 (each within the scatter of the next, the first and the last beyond it).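

In this assay, butoxycarbonyl on this aromatic carbon is not separated from the other two groups: a 1.3-fold lower number from compound 3 to compound 4 (0.10 log units; within the scatter) and a 1.8-fold lower number from compound 2 to compound 4 (0.26 log units; within the scatter) leave all three substituents indistinguishable. Inverting the drawn stereocentre also gives no step beyond the scatter, at a 2.0-fold higher number from compound 1 to compound 4 (0.30 log units; within the scatter), so no preference for either configuration can be claimed, and the comparison is clean on one point: the fact that compounds 1 and 4 differ only in the configuration as drawn

From the compounds shown here alone, it remains open whether a carboxylic acid or an amine on this aromatic carbon, or a longer chain in the ester, gives a step beyond the scatter. Going by these compounds, it also remains open whether the stereocentre matters with methoxy or isopropyl in place of butoxycarbonyl.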